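Aryl variation on the shared nucleoside core

The compounds below may be only part of what the source reports. "The series", "measured", "known", "first", "only" and "open" are said of these compounds alone.

Measured compounds:
compound 1 `COc1ncnc2c1c(-c1ccsc1)cn2[C@@H]1O[C@H](CO)[C@@H](O)[C@H]1O` — 140 nM
compound 2 `COc1ncnc2c1c(-c1cccs1)cn2[C@@H]1O[C@H](CO)[C@@H](O)[C@H]1O` — 440 nM

Two compounds have numbers in a functional assay on HCT-116 cells (Homo sapiens), read by MTT assay, with a stated time of 72 h; a higher number here means a weaker inhibitor, a lower number a stronger inhibitor. For the measured compounds named here, compound 2 stands at the higher of the two; its nearest neighbour is compound 1, and the only measured step, a 3.1-fold higher number from compound 1 to compound 2 (0.50 log units; beyond the scatter), separates them, with thiophen-2-yl in place of thiophen-3-yl on an aromatic carbon.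

Compound 3 `COc1ncnc2c1c(-c1ccccc1)cn2[C@@H]1O[C@H](CO)[C@@H](O)[C@H]1O` is not yet measured. It differs from compound 2 as follows: phenyl in place of thiophen-2-yl on an aromatic carbon

Going by the values given here, no measured step involves phenyl, so the bearing of the data on this change is indirect. Among the compounds with values here, the single step from compound 1 to compound 2 shows that altering the aryl group at this position moves the number in this assay by a modest amount, and a change of comparable or smaller size is the reasonable expectation here. The direction cannot be read from the two values; a number at or somewhat below that of compound 2 is expected, and compound 3 is estimated at 250 nM, within 80 nM to 800 nM, corresponding to an expected step of a 1.8-fold lower number from compound 2 to compound 3 (0.25 log units; within the scatter).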

Compound 3, half-maximal inhibitory concentration: > 20000 nM
Compound 3 was reported as a limit; the forecaster's own chance of this, stated with the estimate: 2%; at least 80-fold (1.90 log units) between middle value and limit.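

In this assay the aryl position on the shared core proves far less forgiving than the thiophene pair alone suggested: phenyl in place of thiophen-2-yl gives an at least 45-fold higher number from compound 2 to compound 3 (1.65 log units; beyond the scatter), and phenyl in place of thiophen-3-yl gives an at least 140-fold higher number from compound 1 to compound 3 (2.15 log units; beyond the scatter). The two thiophenes stand together on one side of this change and phenyl on the other, and the difference between the two thiophene attachments, a 3.1-fold higher number from compound 1 to compound 2 (0.50 log units; beyond the scatter), is small beside the change of ring. Compound 3 is reported only as a limit of the assay: the limit of > 20000 nM in this assay, at which 1 of the 3 values shown sits.

As far as these compounds go, it remains open whether this loss belongs to six-membered aromatic rings in general or to phenyl alone; a pyridine ring, or a five-membered furan ring, would help to separate the two readings. Also open, from the compounds shown here alone, is whether a phenyl ring carrying an amine or a carboxylic acid stays at the limit of compound 3 or returns towards the thiophene values.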